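Ring Swap on Compound 1: What to Expect Next

The source may report more compounds than this note shows. Statements on the series, on what has been measured and on what is new or still open speak of the compounds shown alone.

Compound 1 `Cn1cc(-c2ccccc2NCC2=NCCN2)cn1` — 0%
Compound 2 `CC(C)n1nccc1-c1ccccc1NCC1=NCCN1` — 0%

Of the compounds shown here, two have been measured in a functional assay with Alpha-1D adrenergic receptor (Homo sapiens) as the target, read by calcium flux; on this read-out lower numbers stand for smaller maximal responses and higher numbers for larger maximal responses. Compound 1 gives 0% there. Compound 2 gives 0% in this assay. Compound 1 thus stands level with compound 2 at the digits shown; the two values lie within the usual scatter of each other, so nothing can be said of an order between them. For the measured compounds named here, no pair of measured compounds differs in only one place, so no single structural step has yet been tied to a change in this assay.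

Compound 3 `Cn1ccnc1-c1ccccc1NCC1=NCCN1` is not yet measured. It differs from compound 1 in one place: 1-methyl-1H-imidazol-2-yl in place of 1-methyl-1H-pyrazol-4-yl on an aromatic carbon. Because both compound 1 with 0% and compound 2 with 0% sit at the same level, the step from compound 1 to compound 3 is expected to be no change at the digits printed from compound 1 to compound 3 (within the scatter), none beyond the scatter. Compound 3 is estimated at 0%, with a range from 0% to 12%.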

Compound 3, largest response reached (reported as maximal response), in percent of the reference or control that the assay uses: 92%
Compound 3: the middle estimate sits 92 percentage points below what was measured; measured number above the stated range.
By their numbers in this assay, from the lowest: compounds 1 and 2 (each within the scatter of the next); then compound 3.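

In this assay, putting 1-methyl-1H-imidazol-2-yl in place of 1-methyl-1H-pyrazol-4-yl gives a number 92 percentage points higher from compound 1 to compound 3 (beyond the scatter), so this place on the six-membered aromatic ring of carbon only, ortho to a group of 7 heavy atoms, can carry a large change in the read-out. The two groups have the same atoms and the same counts of hetero atoms, hydrogen-bond donors and hydrogen-bond acceptors, so these counts do not separate the two compounds, and the change lies only in how the atoms are joined. No measurement at hand accounts for the step.

The compounds shown leave open what a 1H-imidazol-2-yl without the methyl, a thiazol-2-yl or a pyridin-2-yl would give at this place in this assay as a maximal response. They also leave open whether an ethyl in place of the methyl on the imidazole would keep the higher number.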